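Series notes: chloro to hydrogen step toward compound 4

A few compounds are considered here, and "the series" means these few. Any claim that something is new, unique, unknown or untested is made for them only; others in the source may bear on it.

Measured in a functional assay on HT-29 cells (Homo sapiens) for cytotoxicity, read by sulforhodamine B assay; on this read-out higher numbers stand for weaker inhibition of growth and lower numbers for stronger inhibition of growth:
compound 1, `COc1ccc(-n2n[o+]c([O-])c2-c2nn3cc(-c4cc5ccccc5oc4=O)nc3s2)cc1`, gives 3.14 ug/mL
compound 2, `COc1ccc(-n2n[o+]c([O-])c2-c2nn3cc(-c4cc5cc(Cl)ccc5oc4=O)nc3s2)cc1`, gives 3.68 ug/mL
compound 3, `O=c1oc2ccc(Br)cc2cc1-c1cn2nc(-c3c([O-])[o+]nn3-c3ccc(Cl)cc3)sc2n1`, gives 5.25 ug/mL

Compound 2 and compound 1 differ in one place: hydrogen in place of chloro on an aromatic carbon. The step is a 1.2-fold lower number from compound 2 to compound 1 (0.07 log units; within the scatter). The difference between the core of compound 3 and the core of compound 2 is not broken down here; compound 3 has the highest of the three numbers, and its gaps to compound 2 and compound 1 both lie within the scatter.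

Compound 4, `O=c1oc2ccc(Br)cc2cc1-c1cn2nc(-c3c([O-])[o+]nn3-c3ccccc3)sc2n1`, is still to be measured in this assay. It differs from compound 3 thus: hydrogen in place of chloro on an aromatic carbon. This is the same kind of change as from compound 2 to compound 1, but not the same: there the carbon sat on a ring that is part of a fused or bridged system of two rings, meta to a fused ring and para to a fused ring; here it sits on a six-membered aromatic ring of carbon only, para to a large group. A small step is expected because a 1.2-fold lower number from compound 2 to compound 1 (0.07 log units; within the scatter) stayed within the scatter, so the estimated step is a 1.1-fold lower number from compound 3 to compound 4 (0.04 log units; within the scatter). Compound 4 is expected at 4.8 ug/mL, estimated between 2.4 ug/mL and 9.5 ug/mL.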

Compound 4, concentration for 50% growth inhibition: 5.6 ug/mL
Compound 4: middle estimate off by 1.2-fold (0.07 log units), on the low side; low and high end bracket the measured number.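

In this assay, hydrogen in place of chloro gives a 1.1-fold higher number from compound 3 to compound 4 (0.03 log units; within the scatter), so the step stays within the scatter on this core as well. The two cores show no difference in this change that can be told apart: the same change on two cores in this assay, a 1.2-fold lower number (0.07 log units; within the scatter) from compound 2 to compound 1 and a 1.1-fold higher number (0.03 log units; within the scatter) from compound 3 to compound 4, 1.3-fold (0.10 log units) apart, within the scatter of two such steps. This supports treating the change as having little effect on the number across these two pairs, but the changed carbon is not the same in both, and two pairs that stay within the scatter do not show how the change would behave on other cores or where a larger step would appear.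

Going by these compounds, it remains open whether an amine or a carboxylic acid on the six-membered aromatic ring of carbon only, para to a large group, would give a step beyond the scatter.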